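Diyne enones on melanoma cells: shortening the terminal chain

This account rests on a few compounds, and the source may have more. Where it says the series, first, only, none or still open, it means among the compounds named here.

As far as these compounds go, the set holds three measured compounds and one still open, all read in a functional assay on SK-MEL-2 cells (Homo sapiens) for cytotoxicity; on this read-out lower numbers stand for an effect already at smaller amounts and higher numbers for an effect only at larger amounts of compound. Compound 1 `C=CCCCCCCCC#CC#C/C=C\C(C)=O` gives 43.1 ug/mL in this assay. Compound 2 `CCCCCCCC#CC#CC1CC(=O)C=C(C)C1` gives 36.7 ug/mL in this assay; the two numbers lie within the usual scatter of each other, so compound 1 merely carries the higher of the two numbers shown and no order between them is claimed. For compound 3 `CCCCCCCC#CC#CC1=CC(=O)NCCC1`, this assay reports only a limit, > 50 ug/mL, and no number; it sits at the limit of > 50 ug/mL in this assay, at which 1 of the 3 values shown sits.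

Compound 4 `CCCCCCCC#CC#C/C=C\C(C)=O` has not yet been measured. It differs from compound 1 as follows: hydrogen in place of vinyl on a saturated chain carbon, seven bonds along the chain from a triple-bonded carbon. Going by the values given here, no measured pair in the set shares this change, so the step is not anchored by data. With the enone and the diyne kept as in compound 1, the step of a 1.0-fold higher number from compound 1 to compound 4 (0.02 log units; within the scatter) in this assay is expected to be small, with no clear direction and probably not beyond the scatter. Compound 4 is therefore estimated at 45 ug/mL in this assay, with a range from 22 ug/mL to 95 ug/mL.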

Compound 4, concentration for half-maximal effect: 42.6 ug/mL
Beside the measured number, compound 4's estimate is 1.1-fold (0.02 log units) above it, and the stated range covers the measured number.
By their numbers in this assay, from the lowest: compounds 2, 4 and 1 (each within the scatter of the next). At a limit, above all of these: compound 3.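

Replacing vinyl with hydrogen on a saturated chain carbon, seven bonds along the chain from a triple-bonded carbon, gives a 1.0-fold lower number from compound 1 to compound 4 (0.01 log units; within the scatter) in this assay. Going by these compounds alone, this is the first reading at this position, and it shows that the read-out does not resolve the loss of the vinyl group, with its double bond and two carbons, from the chain of compound 1. No measurement shown gives a cause for this step.

The compounds shown compare only vinyl and hydrogen at this place, so the outcome with an amine, a carboxylic acid or a longer chain there remains open. Also open, as far as these compounds go, is whether the same change would read alike on the cores of compound 2 and compound 3.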